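Swapping the furan amide for a benzodioxane arm

The source may report more compounds than this note shows. Statements on the series, on what has been measured and on what is new or still open speak of the compounds shown alone.

Measured compounds:
- compound 1 `CC(C)Oc1ccccc1N1CCN(CCCCCCCn2ncc(N3CCN(C(=O)c4ccco4)CC3)c(Cl)c2=O)CC1`: 0.052 nM
- compound 2 `CCOc1ccccc1N1CCN(CCCCCCCn2ncc(Cl)c(N3CCN(C(=O)c4ccco4)CC3)c2=O)CC1`: 0.23 nM

Of the compounds shown here, two share one long core and have been tested in an assay on cell membranes for binding affinity to Adrenergic receptor alpha-1 (Rattus norvegicus), read by radioligand binding; on this read-out lower numbers stand for stronger inhibition and higher numbers for weaker inhibition. Compound 1 gives 0.052 nM and stands at the lowest number of the two. Compound 2 gives 0.23 nM, a higher number, and the gap between the two lies beyond the usual scatter of repeated measurements, so compound 1 is the more tightly binding of the pair. No single-point comparison between the two has been worked out, so only their two values are spoken of here.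

Compound 3 `CC(C)Oc1ccccc1N1CCN(CCCCCCCn2ncc(N3CCN(CC4COc5ccccc5O4)CC3)c(Cl)c2=O)CC1` has not yet been measured. It differs from compound 1 in one place: (2,3-dihydro-1,4-benzodioxin-2-yl)methyl in place of (furan-2-yl)carbonyl on an amine nitrogen in a ring. For the measured compounds named here, nothing among the measured compounds shows what this exchange does, so the size of the step from compound 1 to compound 3 in this assay is open; a change of modest size, in either direction, is expected, most likely within or just beyond the scatter. Compound 3 is expected to give about 0.1 nM, within a range from 0.02 nM to 0.6 nM, which corresponds to an expected 1.9-fold higher number from compound 1 to compound 3 (0.28 log units; within the scatter).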

Compound 3, inhibition constant: 0.31 nM
For compound 3 the middle estimate is 3.1-fold (0.49 log units) below the measured one; the measured number falls inside the stated range.
By their numbers in this assay, from the lowest: compound 1; then compounds 2 and 3 (each within the scatter of the next).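

In this assay, for the compounds shown here, putting (2,3-dihydro-1,4-benzodioxin-2-yl)methyl in place of (furan-2-yl)carbonyl on an amine nitrogen in a ring gives a 6.0-fold higher number from compound 1 to compound 3 (0.78 log units; beyond the scatter) and is the first direct reading of this position, where compound 3 still gives 0.31 nM in spite of the exchange. The position therefore accepts a larger group that has a six-membered aromatic ring of carbon only and no double bond outside aromatic rings, at a cost that lies beyond the usual scatter, while the counts of hydrogen-bond donors and acceptors stay the same on both sides. Nothing measured here explains why the number rises with this exchange.

This single step changes the ring system and removes the carbonyl together, so the compounds shown cannot say which of the two matters; a (furan-2-yl)methyl group or a benzoyl group on the same nitrogen would help to separate them. From the compounds shown here alone, it also remains open whether the same exchange would have a similar effect on the core of compound 2, which differs from compound 1 in more than one place.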